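Chloro added to the fluoroanilide of compound 2

The compounds below may be only part of what the source reports. "The series", "measured", "known", "first", "only" and "open" are said of these compounds alone.

Measured in an assay on isolated protein for inhibition of glutathione S-transferase Mu 2 (Homo sapiens), with a stated time of 10 min; on this read-out lower numbers stand for stronger inhibition and higher numbers for weaker inhibition:
compound 1 `O=C(O)CCC(=O)OCCCCCCSc1ccc([N+](=O)[O-])c2nonc12` gives 160 nM
compound 2 `O=C(CCC(=O)OCCCCCCSc1ccc([N+](=O)[O-])c2nonc12)Nc1ccc(F)cc1` gives 320 nM
compound 3 `Cc1ccc(NC(=O)CCC(=O)OCCCCCCSc2ccc([N+](=O)[O-])c3nonc23)cc1` gives 390 nM

Compound 2 lies within the scatter of both other compounds, with a 2.0-fold higher number from compound 1 to compound 2 (0.30 log units; within the scatter) and a 1.2-fold higher number from compound 2 to compound 3 (0.09 log units; within the scatter); only a 2.4-fold higher number from compound 1 to compound 3 (0.39 log units; beyond the scatter) reaches beyond it. Compound 4 `O=C(CCC(=O)OCCCCCCSc1ccc([N+](=O)[O-])c2nonc12)Nc1ccc(F)c(Cl)c1` differs from compound 2 by chloro in place of hydrogen on an aromatic carbon. For the measured compounds named here, no measured step adds a chloro to the anilide ring; the closest comparison, a 1.2-fold higher number from compound 2 to compound 3 (0.09 log units; within the scatter), exchanges one substituent for another on that ring and stays within the scatter, as does the amide formation a 2.0-fold higher number from compound 1 to compound 2 (0.30 log units; within the scatter). A step of a 1.1-fold higher number from compound 2 to compound 4 (0.04 log units; within the scatter) is therefore expected, nothing beyond the scatter. Compound 4 is estimated at 350 nM in this assay, range 150 nM to 800 nM.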

Compound 4, half-maximal inhibitory concentration: 470 nM
Compound 4: the middle estimate sits 1.3-fold (0.13 log units) below what was measured; the range from low to high includes it.
By their numbers in this assay, from the lowest: compounds 1, 2, 3 and 4 (each within the scatter of the next, the first and the last beyond it).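

In this assay, chloro in place of hydrogen on an aromatic carbon ortho to a fluoro group gives a 1.5-fold higher number from compound 2 to compound 4 (0.17 log units; within the scatter) and so stays within the scatter at this position. The change from 4-methylphenyl to 3-chloro-4-fluorophenyl on the amide nitrogen, a 1.2-fold higher number from compound 3 to compound 4 (0.08 log units; within the scatter), also stays within it, whereas the amide compared with the free acid, a 2.9-fold higher number from compound 1 to compound 4 (0.47 log units; beyond the scatter), lies beyond it. Nothing available explains these steps.

On these data alone, whether bromo or methoxy at this position would stay within the scatter remains open, as does chloro on a phenyl ring without the fluoro group.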